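Amide Tail Variations at the Cholesterol Transporter

The source may hold more compounds than are shown below. What is called first, only, known or untested is meant among the compounds shown, and "the series" means these compounds.

Measured compounds:
compound 1, `O=C(CN1CN(c2ccccc2)C2(CCN(C(=O)c3ccc(C4CCCCC4)cc3)CC2)C1=O)NCCCCO`: 10300 nM
compound 2, `CC(C)(C)OC(=O)NC1CCCN(C(=O)CN2CN(c3ccccc3)C3(CCN(C(=O)c4ccc(C5CCCCC5)cc4)CC3)C2=O)C1`: 4400 nM
compound 3, `CC(C)(C)c1ccc(C(=O)N2CCC3(CC2)C(=O)N(CC(=O)N2CCNCC2)CN3c2ccccc2)cc1`: 22000 nM

In an assay on HEK293 cells for displacement of a labelled ligand from NPC1-like intracellular cholesterol transporter 1 (Homo sapiens) (a higher number here means a weaker inhibitor, a lower number a stronger inhibitor), compound 3 stands highest of the three numbers, beyond the scatter from both others; compound 1 gives 10300 nM and compound 2 gives 4400 nM. Compound 4, `CC(C)(C)c1ccc(C(=O)N2CCC3(CC2)C(=O)N(CC(=O)NCCC(=O)O)CN3c2ccccc2)cc1`, differs from compound 3 in a single place: (2-carboxyethyl)amino in place of piperazin-1-yl on a carbonyl carbon. Within the data shown here, no measured pair shows this exact change. Compound 1 carries an open-chain amino amide and sits lower than compound 3, though on a different core, so a small downward step is expected for compound 4, a 1.5-fold lower number from compound 3 to compound 4 (0.17 log units; within the scatter), possibly none beyond the scatter. Compound 4 is therefore estimated at 15000 nM, with a range from 5000 nM to 45000 nM.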

Compound 4, half-maximal inhibitory concentration: 11400 nM
Estimate against measurement, compound 4: 1.3-fold (0.12 log units) above; low and high end bracket the measured number.
By their numbers in this assay, from the lowest: compound 2; then compounds 1, 4 and 3 (each within the scatter of the next, the first and the last beyond it).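

Among these compounds, measured in this assay the exchange of piperazin-1-yl for (2-carboxyethyl)amino on a carbonyl carbon brings a 1.9-fold lower number from compound 3 to compound 4 (0.29 log units; within the scatter) and gives the first direct comparison at this place. Compound 3 and compound 4 stand within the scatter of each other, so an open chain ending in a carboxylic acid and the ring read alike here. Nothing at hand accounts for this result.

The compounds shown leave open how a longer chain ending in a carboxylic acid, its methyl ester or a chain ending in a primary amine would read at this place. They also leave open whether the same exchange would read alike on the core of compound 1.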